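The source may report more compounds than this note shows. Statements on the series, on what has been measured and on what is new or still open speak of the compounds shown alone.

Working notes on the series. In a functional assay on HeLa cells (Homo sapiens) for inhibition, read by sulforhodamine B assay (on this read-out lower numbers stand for stronger inhibition and higher numbers for weaker inhibition), compound 3 (`COc1ccccc1NC1=CC(=O)c2c(nc3n2[C@H]2OC[C@@H](O)[C@H]2OC3)C1=O`) gives 7460 nM and compound 2 (`Cc1ccc(NC2=CC(=O)c3c(nc4n3[C@H]3OC[C@@H](O)[C@H]3OC4)C2=O)cc1`) gives 6590 nM, two values within the scatter of each other. Compound 1 (`O=C1C(NC2CCCC2)=CC(=O)c2c1nc1n2[C@H]2OC[C@@H](O)[C@H]2OC1`) gives > 16000 nM, which is a limit of the assay and not a number.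

Compound 4 (`O=C1C(N2CCCC2)=CC(=O)c2c1nc1n2[C@H]2OC[C@@H](O)[C@H]2OC1`) carries pyrrolidin-1-yl in place of the (2-methoxyphenyl)amino group of compound 3, on a double-bonded ring carbon: pyrrolidin-1-yl in place of (2-methoxyphenyl)amino on a double-bonded ring carbon. The change removes the aromatic ring and the amine hydrogen-bond donor.

Among the compounds with values here, no measured step involves pyrrolidin-1-yl itself, so the nearest guides are the swaps between cyclopentyl and an aromatic ring on the amine nitrogen. With 4-methylphenyl in place of cyclopentyl, the record shows an at least 2.4-fold lower number from compound 1 to compound 2 (0.38 log units; beyond the scatter). With 2-methoxyphenyl in place of cyclopentyl, it shows an at least 2.1-fold lower number from compound 1 to compound 3 (0.33 log units; beyond the scatter). Both steps are modest, and both are bounded by the limit of compound 1. The exchange between the two aromatic groups gives a 1.1-fold higher number from compound 2 to compound 3 (0.05 log units; within the scatter), within the scatter.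

Losing the aromatic ring is therefore expected to give a modest step toward weaker inhibition in this assay. The expected change is a 2.1-fold higher number from compound 3 to compound 4 (0.33 log units; beyond the scatter). For compound 4 the estimated value is 16000 nM, with an expected range of 8000 nM to 32000 nM.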

Compound 4, half-maximal inhibitory concentration: > 16000 nM
Compound 4 ended at the assay's limit; the forecaster's own chance of this, stated with the estimate: 50%; the middle value sits exactly at the limit.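

Compound 4 shows that the earlier loss of potency on leaving the aromatic ring also holds for a ring bound directly through its nitrogen at this double-bonded ring carbon, with no amine hydrogen left: in this assay the change gives an at least 2.1-fold higher number from compound 3 to compound 4 (0.33 log units; beyond the scatter), and the comparison with the 4-methylphenyl analogue gives an at least 2.4-fold higher number from compound 2 to compound 4 (0.38 log units; beyond the scatter). Among the four compounds shown, only compound 2 and compound 3 carry an aromatic ring and only they give values short of the limit, with no compound going against this. Both steps are lower bounds on the true size, and the step between compound 1 and compound 4 cannot be read, as both ends of it are limits: the limit of > 16000 nM in this assay, at which 2 of the 4 values shown sit.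

The compounds shown leave apart the loss of the aromatic ring and the loss of the amine hydrogen, as these two changes occur together in compound 4, and a methyl(phenyl)amino group would keep the ring without that hydrogen. Also open, going by these compounds, is whether any saturated group at this carbon, such as a morpholine ring or a longer alkylamino chain, gives a value short of the limit.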